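Chain extension from compound 2 to compound 3

This account rests on a few compounds, and the source may have more. Where it says the series, first, only, none or still open, it means among the compounds named here.

Compound 1 `Nc1ncnc2c1c(-c1cnc3[nH]ccc3c1)nn2CCCCCCCCC(=O)NO` gives 5460 nM
Compound 2 `Nc1nc2cc(-c3nn(CCCCCC(=O)NO)c4ncnc(N)c34)ccc2o1` gives 21500 nM

In a functional assay on HCT-116 cells (Homo sapiens) for inhibition, read by MTT assay, with a stated time of 72 h (a higher number here means a weaker inhibitor, a lower number a stronger inhibitor), compound 2 holds the higher number of the two, and the gap to compound 1 lies beyond the scatter. Compound 3 `Nc1nc2cc(-c3nn(CCCCCCCCC(=O)NO)c4ncnc(N)c34)ccc2o1` differs from compound 2 by 3-(hydroxycarbamoyl)propyl in place of hydroxycarbamoyl on a saturated chain carbon, five bonds along the chain from an aromatic nitrogen on a saturated chain carbon, five bonds along the chain from an aromatic nitrogen. Going by the values given here, no measured pair shows this change alone, so any expectation is loose. A drop beyond the scatter is expected, to a number near that of compound 1 (5460 nM). The estimate is a 4.3-fold lower number from compound 2 to compound 3 (0.63 log units; beyond the scatter) towards stronger inhibition. In this assay the estimate for compound 3 is 5000 nM (range 1200 nM to 18000 nM).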

Compound 3, half-maximal inhibitory concentration: 2980 nM
For compound 3 the middle estimate is 1.7-fold (0.22 log units) above the measured one, and the stated range covers the measured number.
By their numbers in this assay, from the lowest: compounds 3 and 1 (each within the scatter of the next); then compound 2.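

In this assay, going by these compounds alone, 3-(hydroxycarbamoyl)propyl in place of hydroxycarbamoyl on a saturated chain carbon, five bonds along the chain from an aromatic nitrogen, gives a 7.2-fold lower number from compound 2 to compound 3 (0.86 log units; beyond the scatter), the first reading of this change in a single place. With the chain end held constant, exchanging the group on the aromatic carbon gives a 1.8-fold lower number from compound 1 to compound 3 (0.26 log units; within the scatter), so compound 1 and compound 3 are not separated here. Nothing available accounts for the effect of the chain change.

Open, as far as these compounds go, is whether a longer chain carries the trend further. Also open, from the compounds shown here alone, is whether a carboxylic acid can stand in for the hydroxycarbamoyl end.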